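A few compounds are considered here, and "the series" means these few. Any claim that something is new, unique, unknown or untested is made for them only; others in the source may bear on it.

Series notes. In a physicochemical assay for lipophilicity, measured as octanol-water partition (a higher number here means a more lipophilic compound, a lower number a more polar compound), compound 1 `CC(C)c1ccc(/C=C/C(=O)N[C@@H]2O[C@H](CO)[C@@H](O)[C@H](O)[C@H]2O)cc1` gives 0.296. Compound 3 `C[C@@H](Cc1ccc(C(C)(C)C)cc1)C(=O)N[C@@H]1O[C@H](CO)[C@@H](O)[C@H](O)[C@H]1O` gives 0.379 in this assay, a number that lies within the scatter of compound 1, so the two cannot be told apart. Compound 2 `O=C(N[C@@H]1O[C@H](CO)[C@@H](O)[C@H](O)[C@H]1O)C1=Cc2cc(Cl)ccc2OC1` gives -0.169 in this assay, a number beyond the scatter on the lower side of compound 1; among the three measured numbers compound 1 thus stands second highest, with only compound 2 clearly separated from it. Going by the values given here, no two measured compounds differ in a single place, so no step between measured compounds is known here.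

Compound 4 `COC(=O)c1ccc(/C=C/C(=O)N[C@@H]2O[C@H](CO)[C@@H](O)[C@H](O)[C@H]2O)cc1` is not yet measured. It differs from compound 1 in one place: methoxycarbonyl in place of isopropyl on an aromatic carbon. With the hydrogen-bond acceptors that enter along with the methoxycarbonyl, a downward step in this assay, beyond the scatter, is expected. The estimated step from compound 1 to compound 4 is a number 1.20 log units lower from compound 1 to compound 4 (beyond the scatter). For compound 4 the expected value in this assay is -0.9, with a range from -1.5 to -0.3.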

Compound 4, partition coefficient: -0.805
Compound 4: middle estimate off by 0.10 log units, on the low side; low and high end bracket the measured number.
By their numbers in this assay, from the lowest: compound 4; then compound 2; then compounds 1 and 3 (each within the scatter of the next).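

With methoxycarbonyl in place of isopropyl on an aromatic carbon, para to a large group, the series gains its first single-place step in this assay: a number 1.10 log units lower from compound 1 to compound 4 (beyond the scatter). This position is therefore not indifferent to what it carries, since one substituent change with the rest of the core of compound 1 held constant gives a large step. The entering group brings hydrogen-bond acceptors and a double bond outside aromatic rings, but no measurement separates these features or bears on the origin of the step.

Going by these compounds, whether a carboxylic acid, an amine or a nitrile at this aromatic carbon would give a step of similar size remains open. Also open, on these data alone, is whether the same exchange gives a comparable step on the cores of compound 2 and compound 3.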